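Chloro to nitro at a cytotoxicity limit

A few compounds are considered here, and "the series" means these few. Any claim that something is new, unique, unknown or untested is made for them only; others in the source may bear on it.

Of the compounds shown here, two have been tested so far in a functional assay on HT-29 cells (Homo sapiens) for inhibition, read by MTT assay, with a stated time of 72 h; a lower number here means that less compound is tolerated, a higher number that more compound is tolerated. In this assay compound 1 (`CC(C)(Oc1ccc(CCOc2ccc(NC(=O)c3ccccc3)cc2)cc1)C(=O)NS(=O)(=O)c1ccccc1`) gives 7000 nM as a measured number. Compound 2 (`CC(C)(Oc1ccc(CCOc2ccc(/N=N/c3ccccc3)cc2)cc1)C(=O)NS(=O)(=O)c1ccc(Cl)cc1`) gives > 24000 nM in this assay and this is a limit and not a number. It therefore stands at the limit (the limit of > 24000 nM in this assay, at which 1 of the 2 values shown sits) and has no exact position. Going by the values given here, the two compounds differ in more than one place, so no single measured step is available as a guide.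

The next compound, compound 3 (`CC(C)(Oc1ccc(CCOc2ccc(/N=N/c3ccccc3)cc2)cc1)C(=O)NS(=O)(=O)c1ccc([N+](=O)[O-])cc1`), keeps the rest of compound 2 and changes one group. It has nitro in place of chloro on an aromatic carbon, with 4-chlorophenyl becoming 4-nitrophenyl (nitro in place of chloro on an aromatic carbon). Among the compounds with values here, with no measured step for this swap, no direction can be favoured, and a shift beyond the usual scatter in this assay is not expected. The expected change is a number no higher from compound 2 to compound 3 (the limit leaves the size open) and it may well end in another limit. The estimated value for compound 3 is 24000 nM in this assay, with an expected range from 9000 nM to 48000 nM as its bounds.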

Compound 3, half-maximal cytotoxic concentration: > 24000 nM
Compound 3: only a limit was reported; the forecaster's own chance of this, stated with the estimate: 55%; the middle value lies on the limit itself.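

Compound 3 stands at a limit and not at a number in this assay, as compound 2 does, so no step can be read between compound 2 and compound 3: the limit of > 24000 nM in this assay, at which 2 of the 3 values shown sit.

The compounds shown leave open whether nitro in place of chloro changes the cytotoxic concentration in this assay at all, and in which direction.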